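This account rests on a few compounds, and the source may have more. Where it says the series, first, only, none or still open, it means among the compounds named here.

Measured so far in an ADME assay for permeability, using PAMPA, with a stated time of 30 min, at pH 7.4; a higher number here means that the compound crosses the layer faster, a lower number that the compound crosses the layer more slowly:
compound 1, `COc1ccc(Oc2ccc3c(NCCCNCc4cc(F)ccc4OC)ccnc3c2)cc1`: 317 10^-6 cm/s
compound 2, `COc1ccc(F)cc1CNCCCNc1ccnc2cc(Oc3ccc(F)cc3)ccc12`: 317 10^-6 cm/s
compound 3, `COc1ccc(F)cc1CNCCCNc1ccnc2cc(Cc3ccc(F)cc3Cl)ccc12`: 23 10^-6 cm/s

Compound 3 stands lowest of the three numbers in this assay; its nearest neighbour is compound 1 and its furthest is compound 2, both at the same distance from it. The step under consideration leads to compound 4, `COc1ccc(F)cc1CNCCCNc1ccnc2cc(Oc3cccc(N(C)C)c3)ccc12`, which differs from compound 3 in that (3-(dimethylamino)phenoxy in place of 2-chloro-4-fluorobenzyl on an aromatic carbon).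

Going by the values given here, two measured steps bear directly on this change, both in the reverse direction: a 14-fold lower number from compound 1 to compound 3 (1.14 log units; beyond the scatter) and a 14-fold lower number from compound 2 to compound 3 (1.14 log units; beyond the scatter). In each, a substituted phenoxy on the shared core gave way to the 2-chloro-4-fluorobenzyl and the number fell sharply. The step of no change at the digits printed from compound 1 to compound 2 (within the scatter) shows that exchanging one substituent on that phenoxy for another left the number where it was. Going back from the benzyl to a phenoxy, now carrying a dimethylamino group, is therefore expected to raise the number by a large step, an 11-fold higher number from compound 3 to compound 4 (1.04 log units; beyond the scatter). Going by these compounds, whether a dimethylamino-bearing phenoxy lands where the methoxy- and fluoro-bearing ones of compound 1 and compound 2 did is untested in this set, so the range is kept wide. Compound 4 is expected to give 250 10^-6 cm/s in this assay, within a range from 100 10^-6 cm/s to 450 10^-6 cm/s.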

Compound 4, apparent permeability: 317 10^-6 cm/s
Compound 4: middle estimate off by 1.3-fold (0.10 log units), on the low side, within the range that was stated.
By their numbers in this assay, from the lowest: compound 3; then compounds 1, 2 and 4 (each within the scatter of the next).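

In this assay, the 3-(dimethylamino)phenoxy restores the number lost with the 2-chloro-4-fluorobenzyl, giving a 14-fold higher number from compound 3 to compound 4 (1.14 log units; beyond the scatter), so the recovery at this aromatic carbon extends to a phenoxy carrying a nitrogen-bearing substituent and not only the methoxy- and fluoro-bearing ones. On the phenoxy oxygen, the 3-(dimethylamino)phenyl is indistinguishable from the 4-fluorophenyl, with no change at the digits printed from compound 2 to compound 4 (within the scatter), and from the 4-methoxyphenyl, with no change at the digits printed from compound 1 to compound 4 (within the scatter); among these compounds the three phenoxy groups therefore sit together, whichever substituent they carry and at either ring position shown, while compound 3, the only benzyl, stands apart and none of the four goes against this split. Nothing available gives a measured reason for this split or for the identical printed numbers of the phenoxy compounds.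

Going by these compounds, whether the low number of compound 3 follows from the benzyl link or from its chloro substituent stays open, as the step changes both at once; a 2-chloro-4-fluorophenoxy or a 4-fluorobenzyl would separate the two. Also open, on these data alone, is whether the phenoxy ring stays this tolerant with a carboxylic acid on it.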